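The compounds below may be only part of what the source reports. "The series", "measured", "known", "first", "only" and "open" are said of these compounds alone.

In an ADME assay on microsomes from liver (Rattus norvegicus) for metabolic stability (on this read-out higher numbers stand for a longer-lived compound and lower numbers for a shorter-lived compound), compound 1 (`CC(C)C(Cc1ncc[nH]1)c1ccc(-c2ccc3cccc(F)c3c2)[nH]c1=O`) gives < 0.0667 h as its half-life, and this is a limit of the assay and not a number. Compound 2 (`CCn1ncc2c(F)cc(-c3ccc(C(CC)(CC)c4nnc(C)[nH]4)c(=O)[nH]3)cc21`) gives > 3 h as its half-life, which is likewise a limit. Compound 1 thus stands at the short-lived end of the two values, with no exact figure available for it. Compound 3 (`Cc1nc(C(c2ccc(-c3ccc4cccc(F)c4c3)[nH]c2=O)C(C)C)[nH]c1C`) keeps the core of compound 1 and changes in one place, on a saturated chain carbon bound to an aromatic carbon and a saturated chain carbon, where 4,5-dimethyl-1H-imidazol-2-yl comes in place of (1H-imidazol-2-yl)methyl (4,5-dimethyl-1H-imidazol-2-yl in place of (1H-imidazol-2-yl)methyl on a saturated chain carbon bound to an aromatic carbon and a saturated chain carbon). Among the compounds with values here, no pair of measured compounds shows what such a change does, so the expectation rests on compound 1 alone, with its limit of < 0.0667 h as the starting point. The step of an at least 1.0-fold higher number from compound 1 to compound 3 (0.02 log units; that floor lies within the scatter) in this assay is expected to stay within the usual scatter, with no clear direction. For compound 3 the half-life is estimated at 0.07 h (expected range 0.03 h to 0.25 h) and the assay may well report only a limit again.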

Compound 3, half-life: 0.0733 h
Beside the measured number, compound 3's estimate is 1.0-fold (0.02 log units) below it, and the stated range covers the measured number.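

In this assay, within the data shown here, compound 3 gives 0.0733 h, a measured number rather than a limit, and so the first exact reading for a group on a saturated chain carbon bound to an aromatic carbon and a saturated chain carbon on this core. Moving from (1H-imidazol-2-yl)methyl to 4,5-dimethyl-1H-imidazol-2-yl at this place gives an at least 1.0-fold higher number from compound 1 to compound 3 (0.04 log units; that floor lies within the scatter), so the change, with one more heavy atom and the same ring type, is not shown to lift the half-life clear of the usual scatter. The true size of this step stays unknown because the reading for compound 1 is a limit of the assay and not a number: the limit of < 0.0667 h in this assay, at which 1 of the 3 values shown sits.

The change alters the link to the ring and adds the two methyl groups in one step, so the compounds shown leave open what each part contributes, and a plain 1H-imidazol-2-yl at the same place would be needed to separate them. Also open, on these data alone, is how a different group there, such as a carboxylic acid or a primary amine, would read in this assay.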